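The source may hold more compounds than are shown below. What is called first, only, known or untested is meant among the compounds shown, and "the series" means these compounds.

Measured compounds:
Compound 1, `Cc1cc(C)cc(S(=O)(=O)n2c(=O)[nH]c3ccc(Cl)cc32)c1`: 39000 nM.
Compound 2, `Cc1cccc(S(=O)(=O)n2c(=O)[nH]c3ccc(Cl)cc32)c1`: > 307000 nM.
Compound 3, `Cc1cc(C)c(C)c(S(=O)(=O)n2c(=O)[nH]c3ccc(Cl)cc32)c1C`: >= 342000 nM.

In an ADME assay on MT4 cells (Homo sapiens) for cytotoxicity (on this read-out higher numbers stand for lower toxicity in this test and lower numbers for higher toxicity in this test), compound 1 gives 39000 nM. The value of compound 2, > 307000 nM, is a limit of the assay and not a number. The change methyl in place of hydrogen on an aromatic carbon produced the step of an at least 7.8-fold lower number from compound 2 to compound 1 (0.89 log units; beyond the scatter), and this step is known only as a limit since compound 2 sits at the limit of > 307000 nM in this assay, at which 1 of the 3 values shown sits. The value of compound 3, >= 342000 nM, is likewise a limit of the assay. How the core of compound 3 differs from the core of compound 2 is not broken down here.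

Compound 4, `Cc1c(C)c(C)c(S(=O)(=O)n2c(=O)[nH]c3ccc(Cl)cc32)c(C)c1C`, is not yet measured. It differs from compound 3 by methyl in place of hydrogen on an aromatic carbon. Within the data shown here, this is the same kind of change as the one from compound 2 to compound 1, but the surroundings are not the same: in compound 4 the entering methyl sits ortho to two methyl groups, meta to two methyl groups and para to a large group, whereas in compound 1 it sits meta to a large group and meta to a methyl group.

Compound 4 is expected in this assay to give about 220000 nM, most likely between 60000 nM and 400000 nM. The expected step of an at least 1.5-fold lower number from compound 3 to compound 4 (0.19 log units; that floor lies within the scatter) is kept small, since compound 3 rests at the limit of >= 342000 nM in this assay, at which 1 of the 3 values shown sits, and its value gives no number to move from. The earlier pair leaves room for a lower number, as the step of an at least 7.8-fold lower number from compound 2 to compound 1 (0.89 log units; beyond the scatter) shows.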

Compound 4, half-maximal cytotoxic concentration: 236000 nM
Compound 4: the middle estimate sits 1.1-fold (0.03 log units) below what was measured; the range from low to high includes it.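

In this assay, methyl in place of hydrogen on an aromatic carbon, carried over to the core of compound 3, gave an at least 1.4-fold lower number from compound 3 to compound 4 (0.16 log units; that floor lies within the scatter), so the direction of the earlier step recurs, but the floor of this step lies within the scatter and shows no change beyond it on its own. The value of compound 3, >= 342000 nM, is a limit of the assay and not a number. The result therefore shows that the new core does not rule out a step as large as the earlier one, yet it does not show that the change carries over with the same size, nor that its size differs between the two cores: the same change on two cores in this assay, an at least 7.8-fold lower number (0.89 log units; beyond the scatter) from compound 2 to compound 1 and an at least 1.4-fold lower number (0.16 log units; that floor lies within the scatter) from compound 3 to compound 4; the limit leaves it open whether they differ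

All the compounds shown carry only methyl groups on this six-membered aromatic ring, so they leave open whether a methoxy group, an amine or a carboxylic acid there would move the read-out in this assay in the same direction. They also leave open how a longer chain in place of a methyl would read, and how large the step is between two compounds that both give a number rather than a limit.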